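Ester Variation on the Lactone Acetal of Compound 1

A few compounds are considered here, and "the series" means these few. Any claim that something is new, unique, unknown or untested is made for them only; others in the source may bear on it.

Compound 1 `CC(=O)O[C@@H]1OC(=O)[C@](C)(C(C)=O)[C@@H]1C` is the parent of the pair measured so far. In a functional assay on HT-29 cells (Homo sapiens) for cytotoxicity, read by MTT assay (on this read-out lower numbers stand for stronger inhibition and higher numbers for weaker inhibition), compound 1 gives 5000 nM, the lowest of the two numbers in hand. Compound 2 `CC(=O)CC[C@]1(C(C)=O)C(=O)O[C@@H](OC(C)=O)[C@H]1C` carries a 2-oxopropyl group on a saturated chain carbon bound to a saturated ring carbon; in this assay compound 2 gives 7000 nM, and the step of a 1.4-fold higher number from compound 1 to compound 2 (0.15 log units; within the scatter) falls within the scatter, so the two compounds cannot be ordered.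

Compound 3 `CC(=O)[C@@]1(C)C(=O)O[C@@H](OC(=O)C(C)(C)C)[C@H]1C` differs from compound 1 elsewhere: tert-butyl in place of methyl on a carbonyl carbon. For the measured compounds named here, no measured step touches the ester on the acetal oxygen; the only step in hand, a 1.4-fold higher number from compound 1 to compound 2 (0.15 log units; within the scatter), concerns a different position and is itself within the scatter, so it offers no direction for this change. With nothing in the series pointing either way, the expectation for compound 3 is a number close to that of compound 1, and the estimated step of no change at the digits printed from compound 1 to compound 3 (within the scatter) is set to stay within the scatter. Compound 3 is therefore expected to give about 5000 nM in this assay, with a plausible range from 2000 nM to 12000 nM.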

Compound 3, half-maximal inhibitory concentration: 2000 nM
Beside the measured number, compound 3's estimate is 2.5-fold (0.40 log units) above it, and the stated range covers the measured number.
By their numbers in this assay, from the lowest: compound 3; then compounds 1 and 2 (each within the scatter of the next).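

In this assay, for the compounds shown here, tert-butyl in place of methyl on a carbonyl carbon gives a 2.5-fold lower number from compound 1 to compound 3 (0.40 log units; beyond the scatter) and this is the first step to lie beyond the scatter, though only modestly. Going by these compounds alone, the only earlier step of a 1.4-fold higher number from compound 1 to compound 2 (0.15 log units; within the scatter) concerns a different place and gave no direction, whereas this one shows that the number responds to the group on this carbonyl carbon and that 4 heavy atoms in place of 1 heavy atom are tolerated here in this read-out, with the number moving down rather than up. Nothing in hand accounts for why the number falls with this change. From the compounds shown here alone, whether the number tracks the group's size stays open, as this single pair gives only the two ends: isopropyl, a longer chain or phenyl on the same carbonyl carbon would show whether the fall is gradual, and whether it continues past tert-butyl. Also open, going by these compounds, are whether an amine or a carboxylic acid in that group keeps the lower number, and whether tert-butyl and the 2-oxopropyl group of compound 2 can be combined on the shared core.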